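Chloro for Methyl on a Series That Shows No Toxicity

The source may hold more compounds than are shown below. What is called first, only, known or untested is meant among the compounds shown, and "the series" means these compounds.

Compound 1 `COc1ccc(-c2cnc(NC(=O)c3ccccc3F)n2C)cc1`: in a toxicity assay on THP-1 cells (Homo sapiens) for inhibition (on this read-out lower numbers stand for higher toxicity in this test and higher numbers for lower toxicity in this test), compound 1 gives > 100000 nM, which is a limit of the assay.
Compound 2 `COc1ccc(-c2cnc(NC(=O)C3CCCC3)n2C)cc1`: in this assay compound 2 gives > 100000 nM, also only a limit.
Compound 3 `COc1ccc(-c2cnc(NC(=O)c3cccc(C)c3)n2C)cc1`: in this assay compound 3 gives > 100000 nM, again a limit.

All three compounds share one core and differ only in the group attached to the carbonyl carbon. Compound 3 stands where the other two stand, at the limit of > 100000 nM in this assay, at which 3 of the 3 values shown sit. All three values are limits, so no order among them can be read, and the steps a step that the two limits leave unreadable from compound 1 to compound 2, a step that the two limits leave unreadable from compound 1 to compound 3 and a step that the two limits leave unreadable from compound 2 to compound 3 are of unreadable size.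

Compound 4 `COc1ccc(-c2cnc(NC(=O)c3cccc(Cl)c3)n2C)cc1` has not yet been measured. It differs from compound 3 by chloro in place of methyl on an aromatic carbon. Within the data shown here, no measured step swaps chloro for methyl, so the only guide is that exchanging the whole group on the carbonyl carbon, in every measured case, left the reading at the limit (the limit of > 100000 nM in this assay, at which 3 of the 3 values shown sit). Compound 4 is therefore expected to sit at or near that same limit, with the step of a number no higher from compound 3 to compound 4 (the limit leaves the size open) expected to be none beyond the scatter. The estimate for compound 4 in this assay is 100000 nM, within a range from 30000 nM to 300000 nM.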

Compound 4, half-maximal cytotoxic concentration: > 28000 nM
Compound 4: no number, only a limit; the forecaster's own chance of this, stated with the estimate: 85%; the middle value does not contradict the limit.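

In this assay compound 4 gives > 28000 nM, which is a limit of the assay and not a number. Among these compounds, compound 1, compound 2 and compound 3 also stand at limits, so no step from any of them to compound 4 can be read. The compounds shown leave open whether chloro and methyl differ at all in this assay, and at what concentration, if any, these compounds turn toxic.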